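Compound 3: a morpholine amide swapped for a chlorobenzyl amide

The compounds below may be only part of what the source reports. "The series", "measured", "known", "first", "only" and "open" are said of these compounds alone.

Compound 1 `Cc1ccsc1C(=CCCN(C)C(CCO)C(=O)N1CCOCC1)c1sccc1C` gives 4.75
Compound 2 `Cc1ccsc1C(=CCCN(C)C(CO)C(=O)NCc1ccccc1)c1sccc1C` gives 6.26

Going by the values given here, in a physicochemical assay for lipophilicity, read by HPLC (a lower number here means a more polar compound, a higher number a more lipophilic compound), compound 1 holds the lower of the two numbers so far. Compound 2 lies above it by more than the usual scatter, so compound 2 is clearly the more lipophilic of the pair.

Compound 3 `Cc1ccsc1C(=CCCN(C)C(CCO)C(=O)NCc1ccccc1Cl)c1sccc1C` has not yet been measured. It keeps the core of compound 1 and differs in one place, on a carbonyl carbon, where (2-chlorobenzyl)amino stands in place of morpholin-4-yl ((2-chlorobenzyl)amino in place of morpholin-4-yl on a carbonyl carbon).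

Among the compounds with values here, no measured pair shows this change on its own, so its size cannot be read directly from the data. Within the data shown here, the only other reference is compound 2 (6.26), and it gives a rough guide to how high a number in this small series can reach. On that thin basis, a rise in this assay is expected, beyond the scatter. The estimated step is a number 1.75 log units higher from compound 1 to compound 3 (beyond the scatter) and it carries real uncertainty. For compound 3 the expected value is 6.5 (estimated range 5.9 to 7.1).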

Compound 3, partition coefficient: 6.23
Estimate against measurement, compound 3: 0.27 log units above, within the range that was stated.
By their numbers in this assay, from the lowest: compound 1; then compounds 3 and 2 (each within the scatter of the next).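

In this assay, putting (2-chlorobenzyl)amino in place of morpholin-4-yl on a carbonyl carbon gives a number 1.48 log units higher from compound 1 to compound 3 (beyond the scatter) and that counts as a large step. Going by these compounds alone, this is the first pair that differs in one place only, so it shows that the group on this carbonyl carbon can move the number strongly while the core of compound 1 stays the same. The swap still changes several things at once, since a non-aromatic ring holding oxygen leaves and an aromatic ring, a chlorine and an amide hydrogen enter, and no measurement here explains why the number moves as it does.

Within the data shown here, the single step leaves open which of these parts carries the size of the change. Piperidin-1-yl on the same carbonyl carbon would test the loss of the ring oxygen while keeping a non-aromatic ring, and (2-fluorobenzyl)amino would show whether the step depends on having chlorine on the aromatic ring.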